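Trimming one methoxy from the aryl ketone of compound 2

This account rests on a few compounds, and the source may have more. Where it says the series, first, only, none or still open, it means among the compounds named here.

Compound 1 `COc1cc(-c2cc(/C=C/C(=O)c3ccc(N)cc3)[nH]n2)cc(OC)c1OC`: 2340 nM
Compound 2 `COc1ccc(C(=O)/C=C/c2cc(-c3cc(OC)c(OC)c(OC)c3)n[nH]2)cc1OC`: 1420 nM

Both compounds were tested in a functional assay on SNB-19 cells (Homo sapiens) for inhibition, read by sulforhodamine B assay, with a stated time of 48 h; on this read-out lower numbers stand for stronger inhibition of growth and higher numbers for weaker inhibition of growth. Compound 2 holds the smaller of the two numbers shown, but the step of a 1.6-fold lower number from compound 1 to compound 2 (0.22 log units; within the scatter) lies within the scatter, so the two compounds are not separated by this assay.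

Compound 3 `COc1ccc(C(=O)/C=C/c2cc(-c3cc(OC)c(OC)c(OC)c3)n[nH]2)cc1` differs from compound 2 in one place: hydrogen in place of methoxy on an aromatic carbon. Among the measured compounds shown here, the only measured step, a 1.6-fold lower number from compound 1 to compound 2 (0.22 log units; within the scatter), exchanged the whole aryl group on the carbonyl carbon and produced no change beyond the scatter. For the measured compounds named here, no measured step removes a single methoxy from that ring, so the effect of this change cannot be read directly from the data. Given that the larger exchange on the same ring moved the number only within the scatter, compound 3 is expected to behave much like compound 2, with a step of a 1.1-fold higher number from compound 2 to compound 3 (0.05 log units; within the scatter) that stays within the scatter. The estimate for compound 3 in this assay is therefore 1600 nM, in a range from 500 nM to 5000 nM.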

Compound 3, concentration for 50% growth inhibition: 1510 nM
Compound 3: the middle estimate sits 1.1-fold (0.03 log units) above what was measured; low and high end bracket the measured number.
By their numbers in this assay, from the lowest: compounds 2, 3 and 1 (each within the scatter of the next).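

In this assay, among the compounds shown here, the change from 3,4-dimethoxyphenyl to 4-methoxyphenyl gives a 1.1-fold higher number from compound 2 to compound 3 (0.03 log units; within the scatter) and so tests a single methoxy on an aromatic carbon, ortho to a methoxy group, on its own for the first time; taking that group away leaves the number within the scatter. The earlier step from compound 1 to compound 2 had exchanged amino for methoxy and added a second methoxy in one move, whereas compound 3 isolates the exchange of amino for methoxy, and a 1.5-fold lower number from compound 1 to compound 3 (0.19 log units; within the scatter) shows that this change alone also stays within the scatter. Neither part of the earlier exchange therefore separates these compounds in this assay, and nothing available explains why the numbers lie so close together.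

The compounds shown leave open whether the remaining methoxy on this ring could be replaced by hydrogen, a carboxylic acid, a dimethylamino group or a longer chain such as butoxy with as little effect. They also leave open whether the other aryl group, identical in all three compounds, would respond any more strongly to change.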